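This account rests on a few compounds, and the source may have more. Where it says the series, first, only, none or still open, it means among the compounds named here.

Compound 1 `O=C(NCc1cnnn1Cc1ccc2oc(-c3ccc(Cl)cc3)cc(=O)c2c1)c1ccccc1`: 32900 nM
Compound 2 `O=C(CCc1cn(Cc2ccc3oc(-c4ccccc4)cc(=O)c3c2)nn1)Nc1ccc(F)cc1`: 15600 nM
Compound 3 `Cc1ccc(C(=O)NCc2cn(Cc3ccc4oc(-c5ccc(Cl)cc5)cc(=O)c4c3)nn2)cc1`: 32900 nM

All three were tested in an assay on isolated protein for inhibition of Amine oxidase [flavin-containing] B (Homo sapiens), read by fluorescence and spectrophotometry; a higher number here means a weaker inhibitor, a lower number a stronger inhibitor. Going by the values given here, compound 2 gives the lowest of the three numbers; compound 1 and compound 3 each give a higher number, and both gaps lie beyond the usual scatter, so compound 2 is the strongest inhibitor among the compounds measured so far. Compound 4 `O=C(CCCCc1cn(Cc2ccc3oc(-c4ccccc4)cc(=O)c3c2)nn1)Nc1ccccc1` has not yet been measured. It differs from compound 2 in a single place: 2-(phenylcarbamoyl)ethyl in place of (4-fluorophenyl)carbamoyl on a saturated chain carbon, two bonds along the chain from an aromatic carbon. Among the compounds with values here, no pair of measured compounds shows a change of this kind, so the data offer no direct guide to its size. For this change the writer expects only a small step toward a higher number, estimated as a 1.4-fold higher number from compound 2 to compound 4 (0.15 log units; within the scatter). Compound 4 is expected to give about 22000 nM in this assay, within a range from 8000 nM to 60000 nM.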

Compound 4, half-maximal inhibitory concentration: 15600 nM
Compound 4: the middle estimate sits 1.4-fold (0.15 log units) above what was measured; measured number inside the range.
By their numbers in this assay, from the lowest: compounds 2 and 4 (each within the scatter of the next); then compounds 1 and 3 (each within the scatter of the next).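

In this assay, replacing (4-fluorophenyl)carbamoyl with 2-(phenylcarbamoyl)ethyl on this saturated chain carbon gives no change at the digits printed from compound 2 to compound 4 (within the scatter). Going by these compounds alone, at this position, then, the larger group, which carries no fluorine, leaves the reading within the scatter, the first evidence on a change here. Nothing available explains this result.

The change alters the chain and removes the fluorine together, so the compounds shown do not separate the two, and the two could offset each other. On these data alone, whether an amine or a carboxylic acid at this position would shift the number also stays open.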